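Methoxycarbonyl in Place of Nitro on the Fused Ring

The source may hold more compounds than are shown below. What is called first, only, known or untested is meant among the compounds shown, and "the series" means these compounds.

Of the compounds shown here, two have been measured. Compound 1 `Nc1ccccc1NC(=O)c1ccc(CSC(=S)N2CCc3cc([N+](=O)[O-])ccc32)cc1` carries a nitro group on the fused ring of the shared core, and in a functional assay on HeLa cells (Homo sapiens) for antiproliferative activity, read by CCK-8 assay, with a stated time of 72 h, tested at 2 uM (on this read-out higher numbers stand for a stronger effect at the one concentration tested and lower numbers for a weaker effect), compound 1 gives 32.6%. Compound 2 `Nc1ccccc1NC(=O)c1ccc(CSC(=S)N2CCc3ccc([N+](=O)[O-])cc32)cc1` carries the same nitro group at another position of that ring, and in this assay compound 2 gives 45.7%. Within the data shown here, of the two numbers known, compound 1 stands lowest; its nearest neighbour is compound 2, whose number lies higher by a gap beyond the usual scatter. Among the measured compounds shown here, no pair of measured compounds isolates a single structural change, so no measured step is available to guide the next estimate.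

Compound 3 `COC(=O)c1ccc2c(c1)CCN2C(=S)SCc1ccc(C(=O)Nc2ccccc2N)cc1` differs from compound 1 in one place: methoxycarbonyl in place of nitro on an aromatic carbon. For the measured compounds named here, nothing among the measured compounds shows what this exchange does, so the step is expected to be small and without a clear direction, and the expected change is a number 2.4 percentage points higher from compound 1 to compound 3 (within the scatter), within the scatter. On that basis compound 3 is estimated to give 35% in this assay, with a range from 15% to 55%.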

Compound 3, a percentage reported as inhibition, at one concentration (the size of the read-out at that concentration, not a potency): 45.3%
Compound 3: the middle estimate sits 10.3 percentage points below what was measured; the measured number falls inside the stated range.
By their numbers in this assay, from the lowest: compound 1; then compounds 3 and 2 (each within the scatter of the next).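

In this assay, among these compounds, the exchange of nitro for methoxycarbonyl on this aromatic carbon, meta to a fused ring and para to a fused ring, gives the first step that isolates a single change: a number 12.7 percentage points higher from compound 1 to compound 3 (beyond the scatter). It shows that the nitro group of compound 1 is not needed at this position to keep the read-out at the one concentration tested, since the number rises rather than falls when the slightly larger methoxycarbonyl group enters, with the same count of hydrogen-bond acceptors and no hydrogen-bond donors on either side. The data shown offer no measurement that would explain this modest step, which rests on one pair of compounds.

The compounds shown leave open whether other groups on this same carbon, such as a carboxylic acid, an amine or an ester with a longer chain, would move the number further, or in the opposite direction. They also leave open whether methoxycarbonyl in place of nitro would act in the same way at the position that carries the nitro group in compound 2, and whether a step seen at one concentration would carry over to potency.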